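A few compounds are considered here, and "the series" means these few. Any claim that something is new, unique, unknown or untested is made for them only; others in the source may bear on it.

Among the compounds with values here, compound 1, `C/C(=N\OC(C)C)c1ccc(Sc2cc(F)cc(C3CCOCC3)c2)cc1`, is one of three compounds measured in a functional assay (blood) for inhibition, with Homo sapiens as the target (on this read-out higher numbers stand for weaker inhibition and lower numbers for stronger inhibition), where compound 1 gives 920 nM. That places compound 1 second highest of the three numbers. Compound 2, `C/C(=N\O)c1cccc(Sc2cc(F)cc(C3CCOCC3)c2)c1`, gives 2910 nM in this assay, a higher number than compound 1 and a gap beyond the scatter. Compound 3, `CO[C@]1(c2cc(F)cc(Sc3ccc(/C(C)=N/OCC#N)cc3)c2)CCO[C@@H](C)C1`, gives 40 nM in this assay, far lower than compound 1 and well beyond the scatter; compound 3 differs from compound 1 in several places at once, so its number says nothing about any single change. Compound 4, `CC(=O)O/N=C(\C)c1ccc(Sc2cc(F)cc(C3CCOCC3)c2)cc1`, differs from compound 1 in one place: acetyl in place of isopropyl on an oxygen. Within the data shown here, no step between measured compounds matches this change. Among the measured compounds shown here, the only guidance is compound 2, whose free oxime gives 2910 nM, a weaker result than the isopropyl ether of compound 1. On that basis the step of a 1.6-fold higher number from compound 1 to compound 4 (0.21 log units; within the scatter) is expected to be small and toward weaker inhibition, probably within the scatter. Compound 4 is therefore estimated at 1500 nM, with a range from 500 nM to 5000 nM.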

Compound 4, half-maximal inhibitory concentration: 50 nM
Compound 4: the middle estimate sits 30-fold (1.48 log units) above what was measured; the whole stated range lies above it.
By their numbers in this assay, from the lowest: compounds 3 and 4 (each within the scatter of the next); then compound 1; then compound 2.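

In this assay, the step of an 18-fold lower number from compound 1 to compound 4 (1.26 log units; beyond the scatter) shows that this position is far from indifferent: exchanging isopropyl for acetyl on an oxygen whose other neighbour is a double-bonded nitrogen markedly strengthens inhibition. Both groups count 3 heavy atoms, so the large step comes without any change in that count, while acetyl brings 1 hydrogen-bond acceptor and a double bond that isopropyl lacks. Nothing measured here explains the size of this step.

A single pair cannot show whether the carbonyl alone accounts for the step, or whether a propanoyl or carbamoyl group on the same oxygen would give a similar number. From the compounds shown here alone, it also remains open whether acetyl in place of isopropyl would have a comparable effect on the core of compound 3.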